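Amide variation on the alkynylaniline series

The compounds below may be only part of what the source reports. "The series", "measured", "known", "first", "only" and "open" are said of these compounds alone.

Measured in an assay on isolated protein for inhibition of MAP kinase-interacting serine/threonine-protein kinase 1 (Homo sapiens), read by HTRF, in the presence of a further agent that is not named here; a lower number here means a stronger inhibitor, a higher number a weaker inhibitor:
compound 1 `COC(=O)c1cccc(C#Cc2ccccc2Nc2ncnc3ccc(Cl)nc23)c1` gives > 10000 nM, a limit of the assay.
compound 2 `CCCNC(=O)c1oc2ccc(Nc3ncnc4ccc(Cl)nc34)cc2c1C` gives > 10000 nM, a limit of the assay.
compound 3 `CCCNC(=O)c1cccc(C#Cc2ccccc2Nc2ncnc3ccc(Cl)nc23)c1` gives > 10000 nM, a limit of the assay.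

Compound 3 therefore stands nowhere on a readable scale: its value in this assay is a limit, and the same holds for every other compound measured here, since (the limit of > 10000 nM in this assay, at which 3 of the 3 values shown sit). Going by the values given here, the only step between two measured compounds, a step that the two limits leave unreadable from compound 1 to compound 3, is likewise unreadable, so the exchange of one amide substituent for another has given no measurable shift so far.

Compound 4 `O=C(c1cccc(C#Cc2ccccc2Nc2ncnc3ccc(Cl)nc23)c1)N1CCOCC1` differs from compound 3 in one place: morpholin-4-yl in place of propylamino on a carbonyl carbon. Among the compounds with values here, no measured step bears on this change with a readable size; the amide variation from compound 1 to compound 3 stayed at the limit. The expectation is therefore that compound 4 remains at the limit in this assay, and the step that the limit leaves unreadable from compound 3 to compound 4 is expected to show nothing beyond the scatter. For compound 4 the estimate is 15000 nM, with a range from 4000 nM to 60000 nM.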

Compound 4, half-maximal inhibitory concentration: > 10000 nM
Compound 4 was reported as a limit (the forecaster's own chance of this, stated with the estimate: 80%); the middle value is on the limit's open side.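

Compound 4 is also reported as a limit, so the steps from compound 1 and from compound 3 to compound 4 cannot be read: the limit of > 10000 nM in this assay, at which 4 of the 4 values shown sit.

The compounds shown leave open whether any substituent on this carbonyl carbon affects inhibition at all.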